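Thioether chain length in the shared-core series

This account rests on a few compounds, and the source may have more. Where it says the series, first, only, none or still open, it means among the compounds named here.

Compound 3 `Cc1cc(N2CC[C@@H](C)[C@@H](N(C)c3ncnc4[nH]ccc34)C2)n2nc(SCCCc3ccccc3)nc2n1` stands at the bottom of the numbers gathered so far. In a functional assay on BGC-823 cells (Homo sapiens) for inhibition, read by MTT assay, with a stated time of 72 h (on this read-out higher numbers stand for weaker inhibition and lower numbers for stronger inhibition), compound 3 gives > 100000 nM, which is a limit of the assay and not a number (the limit of > 100000 nM in this assay, at which 1 of the 3 values shown sits). Its two neighbours carry shorter substituents on the sulfur: compound 1 `Cc1cc(N2CC[C@@H](C)[C@@H](N(C)c3ncnc4[nH]ccc34)C2)n2nc(SCc3cc(Cl)ccc3Cl)nc2n1` gives 18900 nM in this assay, and compound 2 `Cc1cc(N2CC[C@@H](C)[C@@H](N(C)c3ncnc4[nH]ccc34)C2)n2nc(SCCc3ccccc3)nc2n1` gives 28000 nM. The step of an at least 5.2-fold higher number from compound 1 to compound 3 (0.72 log units; beyond the scatter) and the step of an at least 3.5-fold higher number from compound 2 to compound 3 (0.55 log units; beyond the scatter) both run toward weaker inhibition as the chain lengthens, whereas a 1.5-fold higher number from compound 1 to compound 2 (0.17 log units; within the scatter) shows the 2,5-dichlorophenyl and the benzyl variants sitting close together.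

Compound 4 `COc1ccc(CSc2nc3nc(C)cc(N4CC[C@@H](C)[C@@H](N(C)c5ncnc6[nH]ccc56)C4)n3n2)cc1` runs the chain back the other way: 4-methoxyphenyl in place of phenethyl on a saturated chain carbon bound to a sulfur. Among the measured compounds shown here, the steps that bear on this change are the two lengthening steps read in reverse, both beyond the scatter, while the comparison of compound 1 with compound 2 suggests the ring substituent itself matters little within this set. A return toward the numbers of compound 1 and compound 2 is therefore expected, and the expected step is an at least 4.0-fold lower number from compound 3 to compound 4 (0.60 log units; beyond the scatter). Compound 4 is estimated at 25000 nM in this assay, with a range from 10000 nM to 70000 nM.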

Compound 4, half-maximal inhibitory concentration: 69900 nM
Compound 4: middle estimate off by 2.8-fold (0.45 log units), on the low side, and the stated range covers the measured number.
By their numbers in this assay, from the lowest: compounds 1 and 2 (each within the scatter of the next); then compound 4. At a limit, above all of these: compound 3.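

The ring substituent is not silent at this position, contrary to what the close pair of compound 1 and compound 2 suggested: in this assay, the exchange of ring substituents gives a 3.7-fold higher number from compound 1 to compound 4 (0.57 log units; beyond the scatter), and against compound 2 the step is a 2.5-fold higher number from compound 2 to compound 4 (0.40 log units; beyond the scatter). Among the compounds shown here, compound 4 thus goes against the rise with chain length read from the earlier compounds, so the 4-methoxybenzyl group on the sulfur does not fall into line with compound 1 and compound 2, and chain length alone does not order the set. The remaining step, an at least 1.4-fold lower number from compound 3 to compound 4 (0.15 log units; that floor lies within the scatter), is only a floor, and the value of compound 3 is a limit of the assay and not a number: the limit of > 100000 nM in this assay, at which 1 of the 4 values shown sits.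

Chain length and ring substitution remain entangled here, as no two compounds shown carry the same aryl group on chains of different length. A plain benzyl group on the sulfur, or a 4-chlorobenzyl group, would show whether the gap to compound 4 follows the methoxy group or the loss of the two chlorines.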